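Replacing one side of the carbonyl: an unmeasured step

A few compounds are considered here, and "the series" means these few. Any claim that something is new, unique, unknown or untested is made for them only; others in the source may bear on it.

Three compounds have been measured in a functional assay on SK-OV-3 cells (Homo sapiens) for inhibition, read by sulforhodamine B assay, with a stated time of 48 h, tested at 0.01 uM; on this read-out lower numbers stand for a stronger effect and higher numbers for a weaker effect at the one concentration tested:

Compound 1 `O=C(Nc1cccc(-n2cc(-c3ccncc3)c(-c3cc(O)cc(Cl)c3)n2)c1)Nc1ccc(Cl)c(C(F)(F)F)c1` gives 108%.
Compound 2 `O=C(Nc1cccc(-n2cc(-c3ccncc3)c(-c3cc(O)cc(Cl)c3)n2)c1)Nc1ccc(Cl)c(Cl)c1` gives 108%.
Compound 3 `COc1cc(Cl)cc(-c2nn(-c3cccc(NC(=O)Nc4ccc(Cl)c(Cl)c4)c3)cc2-c2ccncc2)c1` gives 100%.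

All three numbers sit close together. The step of no change at the digits printed from compound 1 to compound 2 (within the scatter) and the step of a number 8 percentage points lower from compound 2 to compound 3 (within the scatter) both stay within the scatter, so compound 3, although its number is the lowest of the three, cannot be set apart from compound 1 or compound 2 in this assay.

Compound 4 `COc1cc(Cl)cc(-c2nn(-c3cccc(NC(=O)c4cccc(C(F)(F)F)c4)c3)cc2-c2ccncc2)c1` differs from compound 3 in one place: 3-(trifluoromethyl)phenyl in place of (3,4-dichlorophenyl)amino on a carbonyl carbon. Neither measured step touches this part of the structure; one swaps a group on the far aromatic ring, the other caps the hydroxyl as a methoxy. Within the data shown here, there is therefore no measured step that bears on the change to compound 4, and the three numbers so far show no movement at all in this assay.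

On that basis the expectation for compound 4 is no step beyond the scatter, no change at the digits printed from compound 3 to compound 4 (within the scatter), and its estimated read-out is 100%, with a range from 85% to 115%.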

Compound 4, a percentage reported as activity, at one concentration (the size of the read-out at that concentration, not a potency): 102%
For compound 4 the middle estimate is 2 percentage points below the measured one; measured number inside the range.
By their numbers in this assay, from the lowest: compounds 3, 4, 1 and 2 (each within the scatter of the next).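

Among these compounds, this is the first measured change on this side of the carbonyl, and it is a large one: the whole of (3,4-dichlorophenyl)amino gives way to 3-(trifluoromethyl)phenyl, so the swapped group goes from 1 hydrogen-bond donor to 0 and the carbonyl carbon loses its second amide-type nitrogen. Even so, this assay records a number 2 percentage points higher from compound 3 to compound 4 (within the scatter), so at this single concentration neither that donor nor the two chlorines leave a readable mark on the number. Nothing available accounts for this flat result, and a flat read-out at one low concentration cannot separate the two groups in any wider sense.

As far as these compounds go, it remains open whether a carbonyl carbon bearing a non-aromatic group, such as a simple amine or a longer alkyl chain, would stay equally close. From the compounds shown here alone, it is also open whether compound 3 and compound 4 would separate at higher concentrations.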